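This account rests on a few compounds, and the source may have more. Where it says the series, first, only, none or still open, it means among the compounds named here.

Compound 1 `COC(=O)c1cc(C2=C(c3cc(OC)c(OC)c(OC)c3)C(=O)CC2O[SiH2]C(C)(C)C)ccc1OC` was tested in an ADME assay on HEK293 cells (Homo sapiens) for cytotoxicity, read by MTT assay, with a stated time of 72 h; a lower number here means a stronger inhibitor, a higher number a weaker inhibitor. In this assay compound 1 gives only a limit, > 100 ug/mL. The change to compound 4 `COc1ccc(C2=C(c3cc(OC)c(OC)c(OC)c3)C(=O)CC2O[SiH2]C(C)(C)C)cc1` is hydrogen in place of methoxycarbonyl on an aromatic carbon. Among the measured compounds shown here, one measured step bears on it. Compound 2 `COc1ccc(C2=C(c3cc(OC)c(OC)c(OC)c3)C(=O)C(O)C2)cc1NC(=O)c1ccccc1` gives a limit in this assay, > 100 ug/mL. Compound 3 `COc1ccc(C2=C(c3cc(OC)c(OC)c(OC)c3)C(=O)C(O)C2)cc1` gives 6.3 ug/mL in this assay, and the step of an at least 15-fold lower number from compound 2 to compound 3 (1.20 log units; beyond the scatter) is large, with hydrogen in place of benzamido on an aromatic carbon. Compound 1 and compound 2 both sit at the limit of > 100 ug/mL in this assay, at which 2 of the 3 values shown sit. Removing the substituent on this aromatic carbon is therefore expected to lower the number, and the step of an at least 3.3-fold lower number from compound 1 to compound 4 (0.52 log units; beyond the scatter) is the estimate. Compound 4 is expected to give about 30 ug/mL in this assay, with a range from 8 ug/mL to 100 ug/mL.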

Compound 4, half-maximal inhibitory concentration: > 100 ug/mL
Compound 4: a limit, no number (the forecaster's own chance of this, stated with the estimate: 35%); middle value at least 3.3-fold (0.52 log units) from the limit.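

Compound 1 and compound 4 both give only a limit in this assay, and the step between them cannot be read. The compounds shown leave open whether exchanging methoxycarbonyl for hydrogen on this aromatic carbon changes the number at all.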